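From 4-formylphenyl to naphthalen-1-yl on a shared core

The compounds below may be only part of what the source reports. "The series", "measured", "known", "first", "only" and "open" are said of these compounds alone.

Compound 1 `Brc1cn2ccnc2c(-c2ccc3ncn(C4CCCCC4)c3c2)n1`: 5.21%
Compound 2 `O=Cc1ccc(-c2cn3ccnc3c(-c3ccc4ncn(C5CCCCC5)c4c3)n2)cc1`: 17.5%

Of the compounds shown here, two have been measured in a functional assay on HT-29 cells (Homo sapiens) for inhibition, read by sulforhodamine B assay, with a stated time of 48 h, tested at 10 uM; a lower number here means less inhibition, a higher number more inhibition at the concentration tested (going by the name of the read-out). Compound 1 `Brc1cn2ccnc2c(-c2ccc3ncn(C4CCCCC4)c3c2)n1` gives 5.21%, while compound 2 `O=Cc1ccc(-c2cn3ccnc3c(-c3ccc4ncn(C5CCCCC5)c4c3)n2)cc1` gives 17.5% and so stands highest of the two numbers; the gap between them is a number 12.3 percentage points higher from compound 1 to compound 2 (beyond the scatter). Compound 3 `c1ccc2c(-c3cn4ccnc4c(-c4ccc5ncn(C6CCCCC6)c5c4)n3)cccc2c1` has not yet been measured. It differs from compound 2 in one place: naphthalen-1-yl in place of 4-formylphenyl on an aromatic carbon. Among the compounds with values here, only one measured step touches this aromatic carbon, a number 12.3 percentage points higher from compound 1 to compound 2 (beyond the scatter), and it replaces bromo rather than exchanging one carbon-only aromatic group for a larger one, so it bears only loosely on the new change. Because that step, a number 12.3 percentage points higher from compound 1 to compound 2 (beyond the scatter), was modest, the step of a number 1.5 percentage points lower from compound 2 to compound 3 (within the scatter) is expected to stay within the scatter. Compound 3 is therefore estimated at 16%, with a range from 3% to 32%.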

Compound 3, a percentage reported as inhibition, at one concentration (the size of the read-out at that concentration, not a potency): 4.11%
The estimate for compound 3 lay 11.9 percentage points above the measured number; the measured number falls inside the stated range.
By their numbers in this assay, from the lowest: compounds 3 and 1 (each within the scatter of the next); then compound 2.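

In this assay, a larger aromatic group at this carbon did not keep the gain seen with 4-formylphenyl: naphthalen-1-yl in its place gives a number 13.4 percentage points lower from compound 2 to compound 3 (beyond the scatter), and naphthalen-1-yl in place of bromo gives a number 1.1 percentage points lower from compound 1 to compound 3 (within the scatter). An aromatic group of carbon only at this position therefore does not by itself separate compound 3 from the bromo compound 1, and among these three compounds only compound 2 stands apart. Nothing available explains this difference between compound 2 and compound 3.

The change removes the formyl group and adds a second aromatic ring at once, so the two cannot be told apart here. A plain phenyl, a 4-carboxyphenyl or a 4-aminophenyl group at this carbon would bear on whether the formyl group or the single ring goes with the higher number.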